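Removing the Carbamate From a Nucleoside Analogue

The source may report more compounds than this note shows. Statements on the series, on what has been measured and on what is new or still open speak of the compounds shown alone.

Two compounds carry measurements in this series. Compound 1 `OC[C@@]1(O)CO[C@@H](n2cnc3c(NCc4cccc(Cl)c4)ncnc32)[C@@H]1O` and compound 2 `CNC(=O)OC[C@@]1(O)CO[C@@H](n2cnc3c(N)ncnc32)[C@@H]1O` were both tested in an assay on CHO cells for displacement of a labelled ligand from adenosine receptor A3 (Homo sapiens), tested at 10 uM; a higher number here means more inhibition at the concentration tested (going by the name of the read-out), a lower number less inhibition. There compound 1 gives 43%. In this assay compound 2 gives 26%, the lowest of the two numbers, and the gap to compound 1 lies beyond the usual scatter of the measurement. Compound 3 `Nc1ncnc2c1ncn2[C@@H]1OC[C@](O)(CO)[C@H]1O` has not yet been measured in this assay. It differs from compound 2 in a single place: hydrogen in place of methylcarbamoyl on an oxygen on a saturated carbon. For the measured compounds named here, no measured pair in this set isolates this particular change, so nothing known here shows what it does to the read-out. The step from compound 2 to compound 3 in this assay is therefore expected to be small, a number 4 percentage points lower from compound 2 to compound 3 (within the scatter), in no direction clearly beyond the scatter. For compound 3 the estimated value in this assay is 22%, with a range from 5% to 45%.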

Compound 3, a percentage reported as inhibition, at one concentration (the size of the read-out at that concentration, not a potency): 35%
For compound 3 the middle estimate is 13 percentage points below the measured one; low and high end bracket the measured number.
By their numbers in this assay, from the lowest: compounds 2, 3 and 1 (each within the scatter of the next, the first and the last beyond it).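

In this assay, hydrogen in place of methylcarbamoyl on this oxygen gives a number 9 percentage points higher from compound 2 to compound 3 (within the scatter), so the read-out does not separate the two groups at this position. Compound 3 also gives the series a second single change, hydrogen in place of 3-chlorobenzyl on a nitrogen on an aromatic ring, which gives a number 8 percentage points lower from compound 1 to compound 3 (within the scatter), and thus neither single change moves the number beyond the scatter. Nothing available here offers an explanation for these small steps.

The compounds shown leave open whether an acetyl or an ethylcarbamoyl group on this oxygen, or an amine in place of the hydroxyl, would give a different reading. They also leave open how methylcarbamoyl and 3-chlorobenzyl would behave together on the shared core.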